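This account rests on a few compounds, and the source may have more. Where it says the series, first, only, none or still open, it means among the compounds named here.

Among the compounds with values here, the three compounds measured so far share one core and differ only in the group attached to a saturated chain carbon bound to an aromatic carbon. Compound 1 `Cn1ncc2c(=O)n(-c3ccccc3)c(NCc3cccc(F)c3)nc21`, compound 2 `Cn1ncc2c(=O)n(-c3ccccc3)c(CCc3cccc(F)c3)nc21` and compound 3 `Cn1ncc2c(=O)n(-c3ccccc3)c(CSc3cccc(F)c3)nc21` were tested in an assay on isolated protein for inhibition of retinal dehydrogenase 2 (Homo sapiens), tested at 20 uM; a lower number here means less inhibition, a higher number more inhibition at the concentration tested (going by the name of the read-out). Compound 1 gives 73%, compound 2 gives 41% and compound 3 gives 71%. Compound 3 stands second highest of the three: its gap to compound 1 lies within the scatter, while compound 2 sits well below it, as the step of a number 30 percentage points higher from compound 2 to compound 3 (beyond the scatter) shows.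

Compound 4 `CN(Cc1nc2c(cnn2C)c(=O)n1-c1ccccc1)c1cccc(F)c1` has not yet been measured. The change from compound 3 is a group of 9 heavy atoms (7 carbon, 1 nitrogen, 1 fluorine; one six-membered aromatic ring of carbon only) in place of a group of 8 heavy atoms (6 carbon, 1 fluorine, 1 sulfur; one six-membered aromatic ring of carbon only), on a saturated chain carbon bound to an aromatic carbon. Within the data shown here, the one measured step that bears on it is a number 30 percentage points higher from compound 2 to compound 3 (beyond the scatter), which was modest and went upward. Compound 1, which also carries a nitrogen in its attached group, gives a value close to compound 3. For compound 4 the step of a number 6 percentage points lower from compound 3 to compound 4 (within the scatter) is therefore expected to lie within the scatter. Compound 4 is estimated to give 65%, in a range from 45% to 85%.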

Compound 4, a percentage reported as inhibition, at one concentration (the size of the read-out at that concentration, not a potency): 72%
Estimate against measurement, compound 4: 7 percentage points below, within the range that was stated.
By their numbers in this assay, from the lowest: compound 2; then compounds 3, 4 and 1 (each within the scatter of the next).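

In this assay, replacing the (3-fluorophenyl)sulfanyl group with the nitrogen-containing group of compound 4 gives a number 1 percentage points higher from compound 3 to compound 4 (within the scatter) and shows that, on this saturated chain carbon, a group with nitrogen can take the place of one with sulfur without a change that can be told from the scatter. The comparison with the all-carbon group gives a number 31 percentage points higher from compound 2 to compound 4 (beyond the scatter) and leaves compound 2, the only one of the four whose attached group holds neither sulfur nor nitrogen, clearly apart from the others. No measurement available here speaks to the reason for this pattern.

A 3-fluorophenoxy group, with oxygen as the linking atom, would show whether the pattern extends beyond sulfur and nitrogen. A longer chain between the core and the fluorophenyl ring also remains an open case, and these single-concentration numbers do not give potencies.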